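Swapping fluoro for methoxy on the benzyl ring

A few compounds are considered here, and "the series" means these few. Any claim that something is new, unique, unknown or untested is made for them only; others in the source may bear on it.

Going by the values given here, compound 1 `NC(=O)N1CCN(C(=S)SCc2cn(Cc3ccc(F)cc3)nn2)CC1` was tested in a functional assay on MGC-803 cells (Homo sapiens) for cytotoxicity, read by MTT assay, with a stated time of 72 h (a higher number here means a weaker inhibitor, a lower number a stronger inhibitor), where compound 1 gives 9330 nM; this is the only outright number in the set. Compound 2 `O=C(NC1CCCCC1)N1CCN(C(=S)SCc2cn(Cc3ccc(F)cc3)nn2)CC1` carries a cyclohexyl in place of hydrogen on an amide-type nitrogen. In this assay compound 2 reached only the limit of the assay, > 128000 nM. That change gives an at least 13-fold higher number from compound 1 to compound 2 (1.13 log units; beyond the scatter). Compound 3 `COc1ccc(Cn2cc(CSC(=S)N3CCN(C(N)=O)CC3)nn2)cc1` alters the opposite end of the molecule: methoxy in place of fluoro on an aromatic carbon. No measured step touches this part of the structure, so the cyclohexyl result offers no guide here, and from the numbers shown no shift beyond the usual scatter can be predicted in either direction. Compound 3 is therefore expected to give about 9500 nM, most likely between 4000 nM and 25000 nM. This estimate corresponds to an expected 1.0-fold higher number from compound 1 to compound 3 (0.01 log units; within the scatter).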

Compound 3, half-maximal inhibitory concentration: > 128000 nM
Compound 3: only a limit was reported (the forecaster's own chance of this, stated with the estimate: 10%); middle value at least 13-fold (1.12 log units) from the limit.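

Going from 4-fluorobenzyl to 4-methoxybenzyl, with the rest of compound 1 kept, gives an at least 13-fold higher number from compound 1 to compound 3 (1.13 log units; beyond the scatter) in this assay, so the far end of the molecule, which no earlier step touched, also matters in this test. Compound 3 gives > 128000 nM as a limit of the assay, not a number. On these data alone, the step is therefore a minimum, and its true size stays unknown because the reading stops at this ceiling: the limit of > 128000 nM in this assay, at which 2 of the 3 values shown sit.

As far as these compounds go, whether a chlorine, a methyl or a plain hydrogen at this spot on the ring would keep a value close to that of compound 1 remains open. Also open is why this swap has so large an effect, since nothing shown speaks to the cause.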